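Replacing the Sulfur Substituent of Compound 3

The source may hold more compounds than are shown below. What is called first, only, known or untested is meant among the compounds shown, and "the series" means these compounds.

Compound 1 `FC(F)(F)c1ccc(CSc2nc(Sc3ccccn3)cc(C(F)(F)F)n2)cc1`: > 50000 nM (a limit of the assay)
Compound 2 `FC(F)(F)c1ccc(CSc2nc(Sc3nnnn3-c3ccccc3)cc(C(F)(F)F)n2)cc1`: 12400 nM
Compound 3 `FC(F)(F)c1ccc(CSc2nc(Sc3nncs3)cc(C(F)(F)F)n2)cc1`: 10900 nM

These values come from a functional assay on MGC-803 cells (Homo sapiens) for inhibition, read by MTT assay, with a stated time of 72 h; on this read-out higher numbers stand for weaker inhibition and lower numbers for stronger inhibition. The value of compound 1 is a limit and not a number. Compound 3 cannot be separated from its nearest neighbour: a 1.1-fold lower number from compound 2 to compound 3 (0.06 log units; within the scatter), which is within the scatter. Moving away from the pyridin-2-yl group gave two steps beyond the scatter: an at least 4.0-fold lower number from compound 1 to compound 2 (0.60 log units; beyond the scatter) and an at least 4.5-fold lower number from compound 1 to compound 3 (0.66 log units; beyond the scatter).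

The unmeasured compound 4 `FC(F)(F)c1ccc(CSc2nc(Sc3ncc(-c4ccncc4)s3)cc(C(F)(F)F)n2)cc1` carries 5-(pyridin-4-yl)-1,3-thiazol-2-yl in place of 1,3,4-thiadiazol-2-yl on a sulfur, that is, 5-(pyridin-4-yl)-1,3-thiazol-2-yl in place of 1,3,4-thiadiazol-2-yl on a sulfur. The closest guide is the exchange of 1-phenyl-1H-tetrazol-5-yl for 1,3,4-thiadiazol-2-yl, where losing a second aromatic ring left the number within the scatter: a 1.1-fold lower number from compound 2 to compound 3 (0.06 log units; within the scatter). The steps from compound 1 show that this sulfur substituent can matter, so the expected range stays wide: an at least 4.5-fold lower number from compound 1 to compound 3 (0.66 log units; beyond the scatter). No step beyond the scatter is therefore expected in this assay, and the estimated step is a 1.4-fold lower number from compound 3 to compound 4 (0.13 log units; within the scatter). For compound 4 the estimated value is 8000 nM, with an expected range from 2000 nM to 30000 nM.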

Compound 4, half-maximal inhibitory concentration: 5770 nM
For compound 4 the middle estimate is 1.4-fold (0.14 log units) above the measured one; measured number inside the range.
By their numbers in this assay, from the lowest: compounds 4, 3 and 2 (each within the scatter of the next, the first and the last beyond it). At a limit, above all of these: compound 1.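

The larger 5-(pyridin-4-yl)-1,3-thiazol-2-yl group, with 11 heavy atoms against 5 in 1,3,4-thiadiazol-2-yl, is accommodated on this sulfur in this assay without loss, and a second aromatic ring carried on the five-membered ring leaves a 1.9-fold lower number from compound 3 to compound 4 (0.28 log units; within the scatter). The exchange also separates two compounds that both have a real number, which compound 2 and compound 3 did not do, with a 2.1-fold lower number from compound 2 to compound 4 (0.33 log units; beyond the scatter), although this step is only modest and compound 3 remains within the scatter of both neighbours. The step from the pyridin-2-yl compound reads an at least 8.6-fold lower number from compound 1 to compound 4 (0.93 log units; beyond the scatter), and it is only a bound, as compound 1 stands at a limit and not a number: the limit of > 50000 nM in this assay, at which 1 of the 4 values shown sits.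

On these data alone, it remains open whether the ring nitrogen of the pyridin-4-yl group contributes anything, and whether a primary amine, a morpholine or a carboxylic acid on that outer ring would move the number further in this assay. Also open, as far as these compounds go, is whether any group on this sulfur can take the series well past compound 4, whose value of 5770 nM still lies in the same broad region as the others.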